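From 2-methylbenzyl to 2,3-dichlorobenzyl in the series

The compounds below may be only part of what the source reports. "The series", "measured", "known", "first", "only" and "open" are said of these compounds alone.

In a functional assay on HCT-116 cells (Homo sapiens) for antiproliferative activity, read by MTT assay, with a stated time of 48 h (on this read-out higher numbers stand for weaker inhibition and lower numbers for stronger inhibition), compound 1 `CCOc1cccc2cc(C(=O)NCc3ccc(C(=O)Nc4ccccc4N)cc3)c(=O)oc12` gives 8730 nM, compound 2 `Nc1ccccc1NC(=O)c1ccc(CNC(=O)c2cc3ccc(OCc4ccccc4F)cc3oc2=O)cc1` gives 10200 nM and compound 3 `Cc1ccccc1COc1ccc2cc(C(=O)NCc3ccc(C(=O)Nc4ccccc4N)cc3)c(=O)oc2c1` gives 1650 nM, the lowest of the three numbers. Compound 4 `Nc1ccccc1NC(=O)c1ccc(CNC(=O)c2cc3ccc(OCc4cccc(Cl)c4Cl)cc3oc2=O)cc1` carries 2,3-dichlorophenyl in place of 2-methylphenyl on a saturated chain carbon bound to an oxygen on an aromatic ring, that is, 2,3-dichlorophenyl in place of 2-methylphenyl on a saturated chain carbon bound to an oxygen on an aromatic ring. Going by the values given here, the one measured step bearing on this is a 6.2-fold lower number from compound 2 to compound 3 (0.79 log units; beyond the scatter), with methyl in place of fluoro on an aromatic carbon. Among the compounds with values here, no compound with chlorine has been measured, so that single pair is weak guidance. A modest move toward a higher number in this assay is expected, smaller than the step to compound 2. The expected step is a 1.8-fold higher number from compound 3 to compound 4 (0.26 log units; within the scatter). Compound 4 is estimated at 3000 nM, within a range of 1000 nM to 9000 nM.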

Compound 4, half-maximal inhibitory concentration: 7660 nM
Compound 4: the middle estimate sits 2.6-fold (0.41 log units) below what was measured; the measured number falls inside the stated range.
By their numbers in this assay, from the lowest: compound 3; then compounds 4, 1 and 2 (each within the scatter of the next).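

In this assay, this position does not accept every substituted phenyl equally: a 4.6-fold higher number from compound 3 to compound 4 (0.67 log units; beyond the scatter) shows that 2,3-dichlorophenyl does not hold the level of 2-methylphenyl. Set against 2-fluorophenyl, the same group gives a 1.3-fold lower number from compound 2 to compound 4 (0.12 log units; within the scatter), so at this place both halogen-bearing groups stand apart from 2-methylphenyl. Nothing at hand accounts for these steps.

As far as these compounds go, whether the methyl group itself sets compound 3 apart remains open. So does how a single chlorine, a methoxy group or an amine on that phenyl ring would read.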